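Methylsulfinyl for methylsulfanyl on two triazole cores

The source may report more compounds than this note shows. Statements on the series, on what has been measured and on what is new or still open speak of the compounds shown alone.

Compound 1 `CSc1nnc(-c2ccccc2F)n1C` gives 8.8 mg/kg in a functional assay on the whole organism for antagonist activity, with Mus musculus as the target; a lower number here means that less compound is needed, a higher number that more compound is needed for the effect. Compound 2 `Cn1c(-c2ccccc2F)nnc1[S+](C)[O-]` gives 20 mg/kg in this assay, a step of a 2.3-fold higher number from compound 1 to compound 2 (0.36 log units; beyond the scatter) for the change (a group of 3 heavy atoms (1 carbon, 1 oxygen, 1 sulfur; no ring) in place of a group of 2 heavy atoms (1 carbon, 1 sulfur; no ring), on an aromatic carbon). Compound 3 `CSc1nc(-c2ccccc2)n(C)n1` reaches only a limit in this assay, > 100 mg/kg, as one value of the set does (the limit of > 100 mg/kg in this assay, at which 1 of the 3 values shown sits). The difference between the cores of compound 1 and compound 3 is not broken down here. Compound 4 `Cn1nc([S+](C)[O-])nc1-c1ccccc1` carries the same kind of change as compound 2, (a group of 3 heavy atoms (1 carbon, 1 oxygen, 1 sulfur; no ring) in place of a group of 2 heavy atoms (1 carbon, 1 sulfur; no ring), on an aromatic carbon), though the place differs in its ring surroundings as given. Compound 4 is expected to give 200 mg/kg in this assay, with a range from 60 mg/kg to 700 mg/kg. The expected step that the limit leaves unreadable from compound 3 to compound 4 assumes that the change behaves as in a 2.3-fold higher number from compound 1 to compound 2 (0.36 log units; beyond the scatter), so a limit is again expected.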

Compound 4, dose for half-maximal effect: > 200 mg/kg
Compound 4 ended at the assay's limit; the forecaster's own chance of this, stated with the estimate: 85%; the middle value lies on the limit itself.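

Compound 3 and compound 4 both stand only as limits in this assay, and no step can be read between them. On these data alone, whether replacing methylsulfanyl on the core of compound 3 changes the dose needed, as it does on the core of compound 1, stays open.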